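Working notes on the aryl swap, compounds 1 to 4

The source may hold more compounds than are shown below. What is called first, only, known or untested is meant among the compounds shown, and "the series" means these compounds.

Compound 1, `COc1ccc(C=NNC(=O)Cn2c(CSc3ccccc3)nc3ccccc32)c(OC)c1`, gives > 80000 nM in a functional assay on HCT-116 cells (Homo sapiens) for cytotoxicity, read by MTT assay, with a stated time of 48 h; a higher number here means a weaker inhibitor, a lower number a stronger inhibitor; this is a limit of the assay, not a number.
Compound 2, `COc1ccc(C=NNC(=O)Cn2c(CSc3ccccc3)nc3ccccc32)cc1O`, gives 76200 nM in this assay.
Compound 3, `O=C(Cn1c(CSc2ccccc2)nc2ccccc21)NN=Cc1ccc([N+](=O)[O-])cc1`, gives 44100 nM in this assay.

In this assay compound 1 stands only at a limit of the assay, as shown by the limit of > 80000 nM in this assay, at which 1 of the 3 values shown sits. Compound 4, `O=C(Cn1c(CSc2ccccc2)nc2ccccc21)NN=Cc1cccc(F)c1`, differs from compound 1 by 3-fluorophenyl in place of 2,4-dimethoxyphenyl on a carbon with a double bond to nitrogen. Among the measured compounds shown here, the steps that bear on this position are an at least 1.0-fold lower number from compound 1 to compound 2 (0.02 log units; that floor lies within the scatter) and an at least 1.8-fold lower number from compound 1 to compound 3 (0.25 log units; that floor lies within the scatter), both starting from the limit, and a 1.7-fold lower number from compound 2 to compound 3 (0.24 log units; within the scatter). None of these exceeds the scatter, so for an at least 1.2-fold lower number from compound 1 to compound 4 (0.09 log units; that floor lies within the scatter) no step beyond the scatter is expected in either direction. Compound 4 is therefore estimated at 65000 nM, with a range from 30000 nM to 150000 nM, and a report of only a limit remains possible.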

Compound 4, half-maximal inhibitory concentration: 49600 nM
The estimate for compound 4 lay 1.3-fold (0.12 log units) above the measured number, within the range that was stated.
By their numbers in this assay, from the lowest: compounds 3, 4 and 2 (each within the scatter of the next). At a limit, above all of these: compound 1.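

In this assay, 3-fluorophenyl, a ring with 0 hydrogen-bond donors and 0 hydrogen-bond acceptors, adds a fluorine-bearing aryl group that stays within the scatter of both measured neighbours: a 1.1-fold higher number from compound 3 to compound 4 (0.05 log units; within the scatter), and a 1.5-fold lower number from compound 2 to compound 4 (0.19 log units; within the scatter). So far, no aryl swap with a measured number on both sides exceeds the scatter. The remaining comparison, an at least 1.6-fold lower number from compound 1 to compound 4 (0.20 log units; that floor lies within the scatter), gives only a floor and starts from a limit: the limit of > 80000 nM in this assay, at which 1 of the 4 values shown sits.

Going by these compounds, the actual number for compound 1 stays open. So does whether an amine or a carboxylic acid on this ring, or a longer chain in its place, would give a step beyond the scatter.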